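This account rests on a few compounds, and the source may have more. Where it says the series, first, only, none or still open, it means among the compounds named here.

Measured so far:
compound 1, `Clc1ccc(-c2cc(-c3ccoc3)cc(-c3cccs3)n2)cc1`: 5530 nM
compound 2, `Cc1ccc(-c2cc(-c3ccc(Cl)o3)cc(-c3ccsc3)n2)o1`: a limit of the assay, > 50000 nM
compound 3, `Cc1cccc(-c2cc(-c3ccc(Cl)o3)cc(-c3ccsc3)n2)c1`: 20300 nM

In a functional assay on HeLa cells (Homo sapiens) for cytotoxicity, in the presence of a further agent that is not named here (a higher number here means a weaker inhibitor, a lower number a stronger inhibitor), compound 3 gives the highest of the two numbers shown; compound 1 sits at a lower number, beyond the scatter. Compound 2 reaches only a limit of the assay, (the limit of > 50000 nM in this assay, at which 1 of the 3 values shown sits). Going by the values given here, the only step measured in one place, an at least 2.4-fold lower number from compound 2 to compound 3 (0.39 log units; beyond the scatter), concerns 5-methylfuran-2-yl against 3-methylphenyl and does not touch the change now at hand.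

Compound 4, `Clc1ccc(-c2cc(-c3ccsc3)nc(-c3ccccc3Cl)c2)o1`, differs from compound 3 by 2-chlorophenyl in place of 3-methylphenyl on an aromatic carbon. Among the compounds with values here, compound 1 also carries a chlorophenyl group, but it differs from compound 3 in more than one place, so its value gives no clean step. Within the data shown here, no measured step bears on this exchange, and no step beyond the scatter is expected; the estimated step is a 1.4-fold lower number from compound 3 to compound 4 (0.13 log units; within the scatter). Compound 4 is expected at 15000 nM, in the range 5000 nM to 50000 nM.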

Compound 4, half-maximal inhibitory concentration: 8070 nM
Compound 4: the middle estimate sits 1.9-fold (0.27 log units) above what was measured; the range from low to high includes it.
By their numbers in this assay, from the lowest: compounds 1 and 4 (each within the scatter of the next); then compound 3. At a limit, above all of these: compound 2.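

The exchange of 3-methylphenyl for 2-chlorophenyl next to the ring nitrogen gives a 2.5-fold lower number from compound 3 to compound 4 (0.40 log units; beyond the scatter) in this assay, so this position responds to a change between two phenyl groups of the same heavy-atom count. Going by these compounds alone, replacing 5-methylfuran-2-yl at the same position with 2-chlorophenyl gives an at least 6.1-fold lower number from compound 2 to compound 4 (0.79 log units; beyond the scatter), so 3-methylphenyl is not the only phenyl group below compound 2. Compound 2 stands at a limit of the assay, so that step is a bound only: the limit of > 50000 nM in this assay, at which 1 of the 4 values shown sits.

The 3>4 exchange changes both the substituent on the phenyl ring and where it sits, and the compounds shown do not separate the two. Going by these compounds, the effect of an amine or a carboxylic acid on that phenyl ring also stays open.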